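Ring contraction on the sulfonamide side chain: oxolane to oxetane

A few compounds are considered here, and "the series" means these few. Any claim that something is new, unique, unknown or untested is made for them only; others in the source may bear on it.

Compound 1 `NC(=O)[C@@H](CCC(F)(F)F)N(C[C@@H]1CCCCO1)S(=O)(=O)c1ccc(Cl)cc1` in an in vitro ADME assay on microsomes from liver (Homo sapiens) for metabolic stability, read by HPLC (on this read-out lower numbers stand for slow clearance and higher numbers for fast clearance), gives only a limit, > 300 mL/min/kg. Compound 2 `NC(=O)[C@@H](CCC(F)(F)F)N(C[C@H]1CCCO1)S(=O)(=O)c1ccc(Cl)cc1` gives the one number shown, 231 mL/min/kg. Among the measured compounds shown here, the step of an at least 1.2-fold lower number from compound 1 to compound 2 (0.11 log units; that floor lies within the scatter) is the only measured step, and it sits within the scatter, a floor set by the limit of > 300 mL/min/kg in this assay, at which 1 of the 2 values shown sits. Compound 3 `NC(=O)[C@@H](CCC(F)(F)F)N(C[C@@H]1CCO1)S(=O)(=O)c1ccc(Cl)cc1` carries the next contraction, (oxetan-2-yl in place of oxolan-2-yl on a saturated chain carbon bound to a sulfonamide nitrogen). For the measured compounds named here, no measured step bears on it directly; the one at hand suggests no change beyond the scatter. The step of a 1.2-fold lower number from compound 2 to compound 3 (0.06 log units; within the scatter) is therefore expected to be small. Compound 3 is estimated at 200 mL/min/kg, from 110 mL/min/kg to 300 mL/min/kg.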

Compound 3, clearance: 62.1 mL/min/kg
Beside the measured number, compound 3's estimate is 3.2-fold (0.51 log units) above it; the measured number lies below the stated range.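

In this assay, among the compounds shown here, oxetan-2-yl is the first change at this position, on a saturated chain carbon bound to a sulfonamide nitrogen, to give a step beyond the scatter: a 3.7-fold lower number from compound 2 to compound 3 (0.57 log units; beyond the scatter). The contraction from oxan-2-yl also goes beyond the scatter, an at least 4.8-fold lower number from compound 1 to compound 3 (0.68 log units; beyond the scatter). That step is only a floor, set by the limit on compound 1: the limit of > 300 mL/min/kg in this assay, at which 1 of the 3 values shown sits.

The compounds shown leave open whether the opposite stereocentre of oxetan-2-yl keeps this lower clearance. Also open, going by these compounds, is whether an azetidine ring or an open methoxyethyl chain at this position would match it.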